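The source may hold more compounds than are shown below. What is called first, only, known or untested is meant among the compounds shown, and "the series" means these compounds.

Among the measured compounds shown here, compound 3 `CCCCCCCC/C=C\CCCCCCC(=O)c1nnn(C)n1` is the only one of three measured compounds that gives a number: in an assay on isolated protein for inhibition of Fatty-acid amide hydrolase 1 (Homo sapiens) (a higher number here means a weaker inhibitor, a lower number a stronger inhibitor), compound 3 gives 65 nM. Compound 1 `CCCCCCCC/C=C\CCCCCCC(=O)c1ccccc1` sits at a limit of this assay, > 100000 nM. Compound 2 `CCCCCCCC/C=C\CCCCCCC(=O)c1nccn1C` likewise sits at a limit, > 100000 nM. Against those limits, an at least 1500-fold lower number from compound 1 to compound 3 (3.18 log units; beyond the scatter) and an at least 1500-fold lower number from compound 2 to compound 3 (3.18 log units; beyond the scatter) show how much the tetrazolyl ketone matters.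

Compound 4 `CCCCCCCC/C=C\CCCCCCCC=O` differs from compound 3 by formylmethyl in place of (2-methyl-2H-tetrazol-5-yl)carbonyl on a saturated chain carbon, six bonds along the chain from a double-bonded chain carbon. For the measured compounds named here, no measured step removes this ring; the two steps that do bear on it both show a large loss when it is absent. Compound 4 is therefore expected to give a markedly higher number, an estimated 46-fold higher number from compound 3 to compound 4 (1.66 log units; beyond the scatter), landing around 3000 nM with a range from 500 nM to 30000 nM.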

Compound 4, inhibition constant: 190 nM
For compound 4 the middle estimate is 16-fold (1.20 log units) above the measured one; the whole stated range lies above it.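

In this assay, the tetrazole ring turns out not to be required for a low number, since putting formylmethyl in its place gives only a 2.9-fold higher number from compound 3 to compound 4 (0.47 log units; beyond the scatter) and that step is modest. The ring-free aldehyde also stands far from the phenyl and imidazole ketones, with an at least 520-fold lower number from compound 2 to compound 4 (2.72 log units; beyond the scatter) and with an at least 520-fold lower number from compound 1 to compound 4 (2.72 log units; beyond the scatter) as well. Both of these larger steps start from a limit of the assay: the limit of > 100000 nM in this assay, at which 2 of the 4 values shown sit.

Still open, from the compounds shown here alone, is whether a low number needs the aldehyde carbonyl itself, which a primary alcohol or a carboxylic acid in its place would test. Also open, going by these compounds, is whether another ring on the ketone, such as an oxazole, would behave like the tetrazole.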